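A few compounds are considered here, and "the series" means these few. Any claim that something is new, unique, unknown or untested is made for them only; others in the source may bear on it.

Compound 1 `OC[C@]1(c2ccccc2)NC[C@H](O)[C@H]1O` is a small ring-shaped molecule bearing a phenyl group. In an assay on isolated protein for inhibition of lysosomal alpha-glucosidase (Rattus norvegicus), read by colorimetric assay (a lower number here means a stronger inhibitor, a higher number a weaker inhibitor), compound 1 gives 190 nM. Compound 2 `OC[C@]1(c2ccc(O)cc2)NC[C@H](O)[C@H]1O` carries the same skeleton but with a hydroxy on the aromatic ring; in this assay compound 2 gives 2600 nM. Compound 3 `OC[C@@]1(c2ccc(O)cc2)NC[C@@H](O)[C@@H]1O` is the mirror image of compound 2; in this assay compound 3 gives 11000 nM, the highest of the three numbers.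

Two steps connect these measured compounds. Going from compound 2 to compound 1 the change is hydrogen in place of hydroxy on an aromatic carbon, and it produced a 14-fold lower number from compound 2 to compound 1 (1.14 log units; beyond the scatter). Going from compound 2 to compound 3 the change is the two compounds have the same atoms and bonds and differ only in configuration as drawn: 3 of 3 stereo elements differ (all stereocentres are inverted: mirror images); a stereocentre at a saturated ring carbon is drawn S in compound 2 and R in compound 3; a stereocentre at a saturated ring carbon is drawn S in compound 2 and R in compound 3; a stereocentre at a saturated ring carbon is drawn S in compound 2 and R in compound 3, and it produced a 4.2-fold higher number from compound 2 to compound 3 (0.63 log units; beyond the scatter), a difference that rests on (the fact that compounds 2 and 3 differ only in the configuration as drawn).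

Compound 4 `OC[C@@]1(c2ccccc2)NC[C@@H](O)[C@@H]1O` has not yet been measured in this assay. It relates to compound 3 exactly as compound 1 relates to compound 2: the change is hydrogen in place of hydroxy on an aromatic carbon, made on a core that differs from the core of compound 2 as described by the two compounds have the same atoms and bonds and differ only in configuration as drawn: 3 of 3 stereo elements differ (all stereocentres are inverted: mirror images); a stereocentre at a saturated ring carbon is drawn S in compound 2 and R in compound 3; a stereocentre at a saturated ring carbon is drawn S in compound 2 and R in compound 3; a stereocentre at a saturated ring carbon is drawn S in compound 2 and R in compound 3. For the measured compounds named here, since the place of the change is the same, word for word, in both pairs, this is the same change, and the step it made from compound 2 to compound 1 is the only guide available.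

On that basis compound 4 is expected to give 900 nM in this assay, with a plausible range from 300 nM to 3000 nM, meaning an estimated step of a 12-fold lower number from compound 3 to compound 4 (1.09 log units; beyond the scatter); the expectation rests on the size of a 14-fold lower number from compound 2 to compound 1 (1.14 log units; beyond the scatter) applied to the value of compound 3, 11000 nM.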

Compound 4, half-maximal inhibitory concentration: 904000 nM
For compound 4 the middle estimate is 1000-fold (3.00 log units) below the measured one; measured number above the stated range.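

On the core of compound 3, the same swap of hydroxy for hydrogen in this assay gave an 82-fold higher number from compound 3 to compound 4 (1.91 log units; beyond the scatter) and so moved the number the opposite way, which shows that the step did not carry over from one core to its mirror image: the same change on two cores in this assay, a 14-fold lower number (1.14 log units; beyond the scatter) from compound 2 to compound 1 and an 82-fold higher number (1.91 log units; beyond the scatter) from compound 3 to compound 4, 1100-fold (3.05 log units) apart, beyond the scatter of two such steps. The mirror-image step also differs with the hydroxy absent, at a 4800-fold higher number from compound 1 to compound 4 (3.68 log units; beyond the scatter) compared with a 4.2-fold higher number from compound 2 to compound 3 (0.63 log units; beyond the scatter) when it is present, so the two structural changes cannot be treated as separate, additive steps in this set: the fact that compounds 1 and 4 differ only in the configuration as drawn. This is a single change on a single pair of cores, so it warns against transferring the step between these two cores but does not show why the steps differ or how any other change would behave.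

The compounds shown leave open whether a methoxy, a fluorine or an amine on the aromatic carbon that carries the hydroxy would also give opposite steps on the two cores. They also leave open whether the same reversal would appear with a longer chain in place of the six-membered aromatic ring.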